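The source may hold more compounds than are shown below. What is called first, only, known or untested is meant among the compounds shown, and "the series" means these compounds.

Measured compounds and their binding figures:

Compound 1, `CCN(Cc1ccccc1)c1cc(C)nc(N(CC)c2ccc(C(C)C)cc2Br)n1`, gives 17 nM in an assay on isolated protein for binding affinity to corticotropin-releasing factor receptor 1 (Homo sapiens); a lower number here means a stronger inhibitor, a higher number a weaker inhibitor.
Compound 2, `CCN(c1nc(C)cc(C)n1)c1c(Br)cc(OC)cc1OC`, gives 12 nM in this assay.
Compound 3, `CCCN(CC1CC1)c1cc(C)nc(N(CC)c2ccc(C(C)C)cc2Br)n1`, gives 9 nM in this assay.

Compound 2 sits second highest of the three numbers, and its values against compound 3 and compound 1 both lie within the usual scatter, so no order among them can be stated. Compound 4, `CCN(c1nc(C)cc(C)n1)c1c(Br)cc(N(C)C)cc1OC`, differs from compound 2 by dimethylamino in place of methoxy on an aromatic carbon. Within the data shown here, the only single-point step on record, a 1.9-fold lower number from compound 1 to compound 3 (0.28 log units; within the scatter), changes a different part of the shared core and offers no direct guide to exchanging one group for another on an aromatic carbon. Without a relevant precedent, the expectation in this assay is a step no larger than the scatter, as a 1.3-fold higher number from compound 2 to compound 4 (0.10 log units; within the scatter). Compound 4 is therefore estimated at 15 nM, between 5 nM and 45 nM.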

Compound 4, inhibition constant: 5 nM
Beside the measured number, compound 4's estimate is 3.0-fold (0.48 log units) above it, within the range that was stated.
By their numbers in this assay, from the lowest: compounds 4, 3, 2 and 1 (each within the scatter of the next, the first and the last beyond it).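

In this assay, dimethylamino in place of methoxy on an aromatic carbon, meta to a bromo group and para to a large group, gives a 2.4-fold lower number from compound 2 to compound 4 (0.38 log units; beyond the scatter). This modest change is the first step shown that lies beyond the scatter, so this position responds to the exchange of one group for another. No measured data shown explain the step. From the compounds shown here alone, whether an amine such as methylamino or morpholine, or a longer chain such as ethoxy, would act alike at this position remains open.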